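The compounds below may be only part of what the source reports. "The series", "measured", "known", "first", "only" and "open" are said of these compounds alone.

Of the compounds shown here, three of one shared core have been tested in an assay on isolated protein for binding affinity to adenosine receptor A1 (Rattus norvegicus), in the absence of a further agent; on this read-out lower numbers stand for stronger inhibition and higher numbers for weaker inhibition. Compound 1 `Cc1ccc(C(=O)N[C@@H]2[C@@H](O)[C@H](n3cnc4c(NC5CCCC5)ncnc43)O[C@@H]2C)cc1C` gives 236 nM. Compound 2 `CCc1ccc(C(=O)N[C@@H]2[C@@H](O)[C@H](n3cnc4c(NC5CCCC5)ncnc43)O[C@@H]2C)cc1` gives 240 nM. Compound 3 `Cc1ccc(C(=O)N[C@@H]2[C@@H](O)[C@H](n3cnc4c(NC5CCCC5)ncnc43)O[C@@H]2CO)cc1F` gives 112 nM, the lowest of the three numbers, with compound 1 the nearest and compound 2 the furthest; both gaps lie beyond the scatter.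

The step to compound 4 `O=C(CCCc1cccs1)N[C@@H]1[C@@H](O)[C@H](n2cnc3c(NC4CCCC4)ncnc32)O[C@@H]1CO` is 3-(thiophen-2-yl)propyl in place of 3-fluoro-4-methylphenyl on a carbonyl carbon. An aromatic ring attached directly to the carbonyl is thus replaced by a three-carbon chain ending in a five-membered aromatic ring.

Within the data shown here, only one measured step bears on a change at this carbonyl: a 1.0-fold higher number from compound 1 to compound 2 (0.01 log units; within the scatter). That step swapped one substituted aromatic ring for another and changed nothing beyond the scatter. The present change is of a different kind, since the ring no longer sits on the carbonyl, so that step is a weak guide. A moderate weakening is expected, a 2.2-fold higher number from compound 3 to compound 4 (0.35 log units; beyond the scatter). Compound 4 is therefore estimated at 250 nM, with a range from 60 nM to 1000 nM.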

Compound 4, inhibition constant: 67 nM
Beside the measured number, compound 4's estimate is 3.7-fold (0.57 log units) above it, and the stated range covers the measured number.
By their numbers in this assay, from the lowest: compounds 4 and 3 (each within the scatter of the next); then compounds 1 and 2 (each within the scatter of the next).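

In this assay, replacing 3-fluoro-4-methylphenyl with 3-(thiophen-2-yl)propyl on the carbonyl carbon gives a 1.7-fold lower number from compound 3 to compound 4 (0.22 log units; within the scatter) and so leaves no change that can be told from the scatter. The earlier step at this carbonyl only exchanged one aromatic ring attached directly for another, whereas this one shows that, with the core of compound 3 kept, the aromatic ring need not sit directly on the carbonyl, and that a five-membered ring with a hetero atom can stand in for a six-membered ring of carbon only. Nothing measured here explains this result.

As far as these compounds go, whether the end ring is needed at all stays open, and a plain butyl chain would address that. A shorter chain such as thiophen-2-ylmethyl, or a longer one, would show how much the chain length matters.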